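The compounds below may be only part of what the source reports. "The series", "measured", "known", "first", "only" and "open" are said of these compounds alone.

Three compounds have been measured in a functional assay on HeLa cells (Homo sapiens) for antiproliferative activity, read by WST assay, with a stated time of 24 h; a higher number here means a weaker inhibitor, a lower number a stronger inhibitor:

Compound 1 `C=C[C@]1(C)CC[C@@H](C(=C)CNC(C)(C)C)C[C@H]1C(=C)C` gives 25400 nM.
Compound 2 `C=C[C@]1(C)CC[C@@H](C(=C)CNCCCC)C[C@H]1C(=C)C` gives 10800 nM.
Compound 3 `C=C[C@]1(C)CC[C@@H](C(=C)CNC2CCCCC2)C[C@H]1C(=C)C` gives 3390 nM.

Compound 3 stands at the lowest number of the three, with compound 2 nearest and compound 1 furthest away. Every step within this set moved the number downward: a 2.4-fold lower number from compound 1 to compound 2 (0.37 log units; beyond the scatter), a 3.2-fold lower number from compound 2 to compound 3 (0.50 log units; beyond the scatter) and a 7.5-fold lower number from compound 1 to compound 3 (0.87 log units; beyond the scatter). The shared core never changed; only the group on the amine nitrogen did.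

Compound 4 `C=C[C@]1(C)CC[C@@H](C(=C)CNC2CCCCCCC2)C[C@H]1C(=C)C` takes one more step of the same kind: cyclooctyl in place of cyclohexyl on an amine nitrogen. The two steps that ended in cyclohexyl bear on it most directly, and both were modest and beyond the scatter. Moving from a six-membered ring to an eight-membered ring on the same nitrogen is expected to give, at most, a further modest lowering in this assay, or a change no larger than the scatter. Compound 4 is therefore estimated at 2000 nM, with a range from 800 nM to 5000 nM. That estimate corresponds to an expected step of a 1.7-fold lower number from compound 3 to compound 4 (0.23 log units; within the scatter).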

Compound 4, half-maximal inhibitory concentration: 5900 nM
Compound 4: the middle estimate sits 3.0-fold (0.47 log units) below what was measured; the measured number lies above the stated range.
By their numbers in this assay, from the lowest: compounds 3, 4 and 2 (each within the scatter of the next, the first and the last beyond it); then compound 1.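

In this assay, among these compounds, enlarging the ring on the amine nitrogen from cyclohexyl to cyclooctyl gives a 1.7-fold higher number from compound 3 to compound 4 (0.24 log units; within the scatter) and so does not extend the downward run seen among the earlier compounds. Cyclooctyl also cannot be told apart from the open-chain butyl group, with a 1.8-fold lower number from compound 2 to compound 4 (0.26 log units; within the scatter) for that change, but it still separates from tert-butyl, with a 4.3-fold lower number from compound 1 to compound 4 (0.63 log units; beyond the scatter) as a step beyond the scatter. No measurement at hand explains these differences.

Among the compounds shown here, with only two rings compared, it remains open whether cyclopentyl or cycloheptyl would give a lower number than either, and so whether the six-membered ring marks a real optimum. Going by these compounds, it is also open how a benzyl group, whose ring is aromatic, would behave on this nitrogen.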